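The compounds below may be only part of what the source reports. "The series", "measured", "known", "first", "only" and "open" are said of these compounds alone.

Of the compounds shown here, two built on a shared core have been tested in an assay on isolated protein for inhibition of glucose-6-phosphatase catalytic subunit 1 (Homo sapiens), tested at 100 uM; on this read-out lower numbers stand for less inhibition and higher numbers for more inhibition at the one concentration tested (going by the name of the read-out). Compound 1 `CSc1c(C#N)c(N)c(C#N)c(-c2ccccc2)c1-c1ccccc1` gives 7.4% in this assay. Compound 2 `CSc1c(C)c(-c2ccccc2)c(C#N)c(N)c1C#N`, which carries methyl in place of phenyl on an aromatic carbon, gives 0.96% in this assay. That single change amounts to a number 6.4 percentage points lower from compound 1 to compound 2 (within the scatter), so the two numbers cannot be told apart, and compound 2 stands beside compound 1 rather than clearly under it; both show little inhibition at the one concentration tested.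

Compound 3 `CSc1c(C)c(-c2ccc(Cl)cc2)c(C#N)c(N)c1C#N` has not yet been measured. It differs from compound 2 by chloro in place of hydrogen on an aromatic carbon, the same change read one bond further out being phenyl to 4-chlorophenyl. For the measured compounds named here, no measured step touches this part of the molecule; the only step on record is the one from compound 1 to compound 2, and it stayed within the scatter. With both measured compounds near the floor of this assay and no step beyond the scatter to build on, compound 3 is expected to give 3%, within a range of -6% to 14%. The step expected is a number 2 percentage points higher from compound 2 to compound 3 (within the scatter).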

Compound 3, a percentage reported as inhibition, at one concentration (the size of the read-out at that concentration, not a potency): 19.3%
The estimate for compound 3 lay 16.3 percentage points below the measured number; the whole stated range lies below it.
By their numbers in this assay, from the lowest: compounds 2 and 1 (each within the scatter of the next); then compound 3.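

In this assay, for the compounds shown here, chloro in place of hydrogen on an aromatic carbon of a six-membered aromatic ring of carbon only, para to a large group, gives a number 18.3 percentage points higher from compound 2 to compound 3 (beyond the scatter) and is the first step here to clear the usual scatter. This shows that the read-out can respond to a change at this position, which the earlier step did not touch, and that a single added heavy atom is enough to move it, although the step is modest and comes from one tested concentration, so it says nothing about potency. Nothing available here accounts for the rise.

The compounds shown leave open whether the response is specific to chloro or would also appear with another group in the same place, such as fluoro, methoxy, an amine or a carboxylic acid. They also leave open whether the same chloro change would raise the number on compound 1, which carries phenyl in place of the methyl, and whether a larger response can be reached at this position.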